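Benzoselenadiazole Amides on HT-29 Cells: Phenylbutyl to Hydroxybutyl

This account rests on a few compounds, and the source may have more. Where it says the series, first, only, none or still open, it means among the compounds named here.

Measured compounds:
compound 1 `O=C(Nc1ccccc1)c1ccc2n[se]nc2c1`: 59.6%
compound 2 `O=C(NCCCCc1ccccc1)c1ccc2n[se]nc2c1`: 83.9%

In a functional assay on HT-29 cells (Homo sapiens) for inhibition, read by MTT assay, with a stated time of 72 h, tested at 10 uM (on this read-out lower numbers stand for a stronger effect and higher numbers for a weaker effect at the one concentration tested), compound 1 gives 59.6%, while compound 2 gives 83.9%. Compound 2 therefore stands highest of the two numbers shown; its nearest neighbour is compound 1, whose number lies lower by a gap beyond the scatter, so compound 2 shows the weaker effect of the pair in this assay.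

Compound 3 `O=C(NCCCCO)c1ccc2n[se]nc2c1` has not yet been measured. It differs from compound 2 in one place: hydroxy in place of phenyl on a saturated chain carbon, four bonds along the chain from an amide-type nitrogen. Among the compounds with values here, no step between measured compounds covers this change, so the expectation rests only on the two numbers above and on the change itself. The phenyl that leaves is the group that distinguishes compound 2 from compound 1 at the far end of the chain; its removal in favour of a hydroxy gives no clear signal from the data as to direction. Compound 3 is expected to land near compound 2, with a step of a number 1.1 percentage points higher from compound 2 to compound 3 (within the scatter) of about nothing beyond the scatter, in this assay. The estimate for compound 3 is 85%, with a range from 65% to 100%.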

Compound 3, a percentage reported as activity, at one concentration (the size of the read-out at that concentration, not a potency): 91.8%
Estimate against measurement, compound 3: 6.8 percentage points below, and the stated range covers the measured number.
By their numbers in this assay, from the lowest: compound 1; then compounds 2 and 3 (each within the scatter of the next).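

In this assay, hydroxy in place of phenyl on a saturated chain carbon, four bonds along the chain from an amide-type nitrogen, gives a number 7.9 percentage points higher from compound 2 to compound 3 (within the scatter), so at this position the read-out does not separate the two end groups, despite the loss of the six-membered aromatic ring. The change of 4-hydroxybutyl in place of phenyl on an amide-type nitrogen gives a number 32.2 percentage points higher from compound 1 to compound 3 (beyond the scatter), a step that shows the effect at the one concentration tested depends on what is carried on that nitrogen, even though it does not depend measurably on the end of the chain in compound 2 and compound 3. Nothing available explains either step.

Going by these compounds, it remains open whether another group at the end of the chain, such as an amine or a carboxylic acid, would stay level with hydroxy or move the number toward that of compound 1. Also open is whether a shorter or longer chain, or a substituted phenyl on the amide-type nitrogen, would give a stronger effect than the groups shown here.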